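The source may report more compounds than this note shows. Statements on the series, on what has been measured and on what is new or still open speak of the compounds shown alone.

Compound 1 `O=C(O)c1ccccc1-c1ccc(CCc2ncc(CC3CCCCCC3)[nH]2)cc1`: in an in vitro functional assay on cells for agonist activity at Bombesin receptor subtype-3 (Mus musculus), read by luminescence and calcium flux (on this read-out lower numbers stand for an effect already at smaller amounts and higher numbers for an effect only at larger amounts of compound), compound 1 gives 5.7 nM.
Compound 2 `N#Cc1ccccc1Cc1cnc(CCc2ccc(-c3ccccc3C(=O)O)cc2)[nH]1`: in this assay compound 2 gives 642 nM.
Compound 3 `O=C(O)c1ccccc1-c1ccc(CCc2ncc(Cc3cccc(F)c3)[nH]2)cc1`: in this assay compound 3 gives 7.9 nM.

Compound 1 holds the lowest number of the three. Compound 3 stands within the scatter of it, so no order between those two can be claimed, while compound 2 stands far higher. The unmeasured compound 4 `Cc1ccccc1Cc1cnc(CCc2ccc(-c3ccccc3C(=O)O)cc2)[nH]1` comes from compound 1 by the change (2-methylphenyl in place of cycloheptyl on a saturated chain carbon bound to an aromatic carbon). Two measured steps start from the same place on the shared core. The step of a 110-fold higher number from compound 1 to compound 2 (2.05 log units; beyond the scatter) shows that a 2-cyanophenyl there brings a very large rise. The step of a 1.4-fold higher number from compound 1 to compound 3 (0.14 log units; within the scatter) shows that a 3-fluorophenyl there changes nothing beyond the scatter, and an 81-fold lower number from compound 2 to compound 3 (1.91 log units; beyond the scatter) says the same from the other side. Compound 4 carries an aromatic ring, as compound 3 does, yet its methyl stands on the ring carbon that the name 2-methylphenyl gives, as the nitrile of the 2-cyanophenyl does in compound 2, so the two precedents pull in opposite directions. A rise in this assay is therefore expected for compound 4, but one smaller than a 110-fold higher number from compound 1 to compound 2 (2.05 log units; beyond the scatter). For compound 4 the estimate in this assay is 40 nM, within a range from 8 nM to 300 nM, which means an expected 7.0-fold higher number from compound 1 to compound 4 (0.85 log units; beyond the scatter).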

Compound 4, half-maximal effective concentration: 9.3 nM
Compound 4: the middle estimate sits 4.3-fold (0.63 log units) above what was measured; the range from low to high includes it.
By their numbers in this assay, from the lowest: compounds 1, 3 and 4 (each within the scatter of the next); then compound 2.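

Putting a 2-methylphenyl in place of the cycloheptyl gives a 1.6-fold higher number from compound 1 to compound 4 (0.21 log units; within the scatter) in this assay and, measured against the 3-fluorophenyl, a 1.2-fold higher number from compound 3 to compound 4 (0.07 log units; within the scatter) for the same place, so a saturated ring and two aromatic rings carrying different groups all give numbers that cannot be told apart here. The most informative comparison is a 69-fold lower number from compound 2 to compound 4 (1.84 log units; beyond the scatter). Among the compounds shown here, only one group differs there: methyl stands in place of cyano on an aromatic carbon while everything else stays the same. A group on that ring carbon therefore does not by itself bring the large rise, which among these four compounds appears only with the nitrile of compound 2, the single compound that goes against the otherwise flat picture at this position.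

From the compounds shown here alone, it remains open whether an amine, a methoxy group or a longer chain in place of that methyl would stay close to compound 4 or move towards compound 2. No measurement beyond these assay numbers is available to explain why the nitrile and the methyl part so sharply.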